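Trimming the aminopropyl tail from the weaker binder

This account rests on a few compounds, and the source may have more. Where it says the series, first, only, none or still open, it means among the compounds named here.

Of the compounds shown here, two built on the same core have been measured. Compound 1 `CN(C)CCCNC(=O)c1cc(NC(=O)c2cc(NC(=O)c3nc(NC=O)cn3C)cn2CCCN)cn1C` and compound 2 `CN(C)CCCNC(=O)c1cc(NC(=O)c2nc(NC(=O)c3cc(NC=O)cn3CCCN)cn2C)cn1C` differ in more than one place, so only their two values can be set side by side. In an assay on nucleic acid for binding affinity to Nucleic Acid, at pH 6.5, tested at 3 uM (a higher number here means that the compound stabilises the target more against heat, a lower number that the compound stabilises the target less), compound 1 gives 7 degrees C. In this assay compound 2 gives 0 degrees C, the lowest of the two numbers recorded; compound 1 lies higher by a margin beyond the usual scatter.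

The next compound, compound 3 `CN(C)CCCNC(=O)c1cc(NC(=O)c2nc(NC(=O)c3cc(NC=O)cn3C)cn2C)cn1C`, differs from compound 2 in a single place: hydrogen in place of 2-aminoethyl on a saturated chain carbon bound to an aromatic nitrogen. Cut one bond further out, the same change reads as 3-aminopropyl to methyl on the terminal formylamino pyrrole.

Going by the values given here, no measured pair shows this change, so its size has to be guessed. Compound 2 already gives 0 degrees C, which leaves little room for a further drop, and the expected step of no change at the digits printed from compound 2 to compound 3 (within the scatter) is therefore none beyond the scatter. Compound 3 is expected to give 0 degrees C in this assay, with a range from -1.5 degrees C to 1.5 degrees C.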

Compound 3, shift of the target's melting temperature: 0 degrees C
Compound 3: middle estimate and measured number agree at the digits printed; the range from low to high includes it.
By their numbers in this assay, from the lowest: compounds 2 and 3 (each within the scatter of the next); then compound 1.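

In this assay, exchanging 3-aminopropyl for methyl gives no change at the digits printed from compound 2 to compound 3 (within the scatter), so in this arrangement of the shared core the value does not depend on whether the 3-aminopropyl group or the methyl group is present. The step therefore adds a point that the first two compounds could not give, since they differ in more than one place: the loss of this side chain, taken alone, has a measured result here, yet that result comes from compound 2 at 0 degrees C and says nothing about a compound with a higher value. No measurement at hand accounts for this result.

Compound 1, at 7 degrees C, differs from compound 3 in more than one place, so what separates their values cannot be assigned to any single part of the structure. From the compounds shown here alone, it remains open whether the same exchange would leave the value unchanged in a compound that does stabilise the target, and whether a longer chain ending in an amine, or a carboxylic acid, on a saturated chain carbon bound to an aromatic nitrogen would give a different number in this assay from the one seen here.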